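The compounds below may be only part of what the source reports. "The series", "measured", "known", "first", "only" and "open" are said of these compounds alone.

Three amides built on one shared core have been tested in a functional assay on MIA PaCa-2 cells (Homo sapiens) for inhibition, read by MTT assay, with a stated time of 72 h; on this read-out lower numbers stand for stronger inhibition and higher numbers for weaker inhibition. Compound 1 `O=C(Nc1cccc2cccnc12)c1cnc(Cl)cn1` gives 7000 nM, and compound 3 `O=C(Nc1cccc2cccnc12)c1cccnn1` gives 8500 nM, so these two numbers lie within the scatter of each other. Compound 2 `O=C(Nc1cccc2cccnc12)c1ccc(F)nc1` reads > 10000 nM, which is a limit of the assay and not a number. Within the data shown here, compound 3 therefore stands with compound 1 as one of only two true numbers, and no tested pair differs in a single place, so no measured step is available as a guide.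

Compound 4 `O=C(Nc1cccc2cccnc12)c1ncccn1` has the same atoms as compound 3, joined differently, with pyrimidin-2-yl in place of pyridazin-3-yl on a carbonyl carbon. Taking compound 3 at 8500 nM as the starting point, no clear direction can be expected in this assay, and any change is expected to stay within the scatter. The expected step is a 1.1-fold lower number from compound 3 to compound 4 (0.05 log units; within the scatter). For compound 4 the estimated value is 7500 nM, with an expected range of 2500 nM to 18000 nM.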

Compound 4, half-maximal inhibitory concentration: 330 nM
Compound 4: the middle estimate sits 23-fold (1.36 log units) above what was measured, and the stated range ends above it.
By their numbers in this assay, from the lowest: compound 4; then compounds 1 and 3 (each within the scatter of the next). At a limit, above all of these: compound 2.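

In this assay, among these compounds, the swap of pyridazin-3-yl for pyrimidin-2-yl on a carbonyl carbon gives a 26-fold lower number from compound 3 to compound 4 (1.41 log units; beyond the scatter) and is the first measured step. It shows that this place responds strongly to how the ring atoms are joined, even though the two groups match in heavy atoms, hydrogen-bond donors and hydrogen-bond acceptors as counted. Nothing measured here gives a reason for the size of this step.

The compounds shown leave open whether pyridin-2-yl or a plain phenyl ring on the same carbonyl carbon would keep the lower number, and whether a methyl group or an amine added to the pyrimidin-2-yl ring would keep it too. They also leave open whether changes to the shared core would carry the same gain.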